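Shortening the propyl chain on a triazolopyrimidine core

The source may report more compounds than this note shows. Statements on the series, on what has been measured and on what is new or still open speak of the compounds shown alone.

Measured compounds and their numbers in an assay on isolated protein for binding affinity to adenosine receptor A1 (Bos taurus); on this read-out higher numbers stand for weaker inhibition and lower numbers for stronger inhibition:
- compound 1 `OCCNc1nc(-c2ccccc2)nc2c1nnn2Cc1ccccc1`: 38000000 nM
- compound 2 `OC1CCC(Nc2nc(-c3ccccc3)nc3c2nnn3Cc2ccccc2)CC1`: 2700000 nM
- compound 3 `CCCNc1nc(-c2ccccc2)nc2c1nnn2Cc1ccccc1`: 37000000 nM

Compound 3 stands second highest of the three numbers in this assay. Its nearest neighbour is compound 1, and the two lie within the usual scatter of each other; compound 2 is the furthest away, and the step of a 14-fold higher number from compound 2 to compound 3 (1.14 log units; beyond the scatter) is large.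

Compound 4 `CCNc1nc(-c2ccccc2)nc2c1nnn2Cc1ccccc1` differs from compound 3 in one place: hydrogen in place of methyl on a saturated chain carbon, two bonds along the chain from a nitrogen on an aromatic ring. Put differently, the propylamino group on the core becomes an ethylamino group.

Two measured steps speak to this change. The step of a 1.0-fold lower number from compound 1 to compound 3 (0.01 log units; within the scatter) shows that swapping the group on the same chain carbon, two bonds along the chain from a nitrogen on an aromatic ring, left the number unchanged beyond the scatter. The step of a 14-fold higher number from compound 2 to compound 3 (1.14 log units; beyond the scatter) was large, but there the whole group on the ring nitrogen was replaced, not trimmed by a single carbon. A trimming at the end of a short chain therefore looks like a change of small consequence here, and no step beyond the scatter is expected in this assay.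

For compound 4 the estimated number in this assay is 37000000 nM, between 15000000 nM and 90000000 nM, meaning the expected step of no change at the digits printed from compound 3 to compound 4 (within the scatter).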

Compound 4, inhibition constant: 91000000 nM
Estimate against measurement, compound 4: 2.5-fold (0.39 log units) below; measured number above the stated range.
By their numbers in this assay, from the lowest: compound 2; then compounds 3 and 1 (each within the scatter of the next); then compound 4.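

In this assay, this position proves sensitive to a small trim: the step of a 2.5-fold higher number from compound 3 to compound 4 (0.39 log units; beyond the scatter) is modest but beyond the scatter, so going from propylamino to ethylamino moves the number upward, even though methyl in place of hydroxy on the same chain carbon left it unchanged within the scatter. The step of a 2.4-fold higher number from compound 1 to compound 4 (0.38 log units; beyond the scatter) is also modest, which leaves compound 4, with its ethylamino group, holding the highest number of the set, and the step of a 34-fold higher number from compound 2 to compound 4 (1.53 log units; beyond the scatter) shows that the large distance from the 4-hydroxycyclohexyl of compound 2 has grown. Nothing measured here explains why losing this one carbon shifts the number when the earlier swap on that carbon did not.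

On these data alone, it remains open whether the number would keep rising with a still shorter group, such as methylamino or a plain amine, or would fall again with a longer chain, such as butyl. A plain cyclohexyl group would also help, as compound 2 alone cannot separate the contribution of its ring from that of its hydroxy.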